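A few compounds are considered here, and "the series" means these few. Any claim that something is new, unique, unknown or untested is made for them only; others in the source may bear on it.

Measured compounds:
- compound 1 `O=S(=O)(Nc1ccccc1Cl)c1ccc(-c2cnc(C3CC3)o2)cc1`: 49700 nM
- compound 2 `O=S(=O)(Nc1ccc(F)c(Cl)c1)c1ccc(-c2cnc(C3CC3)o2)cc1`: 73700 nM
- compound 3 `COc1cc(NS(=O)(=O)c2ccc(-c3cnc(C4CC4)o3)cc2)ccc1F`: 75700 nM

All three were read in a functional assay on cells (leukaemia cell line, Homo sapiens) for inhibition, read by sulforhodamine B assay, with a stated time of 48 h; on this read-out lower numbers stand for stronger inhibition of growth and higher numbers for weaker inhibition of growth. Compound 2 gives 73700 nM, the second highest of the three numbers; its nearest neighbour is compound 3 with a 1.0-fold higher number from compound 2 to compound 3 (0.01 log units; within the scatter), its furthest compound 1 with a 1.5-fold higher number from compound 1 to compound 2 (0.17 log units; within the scatter), both within the scatter, so the three compounds cannot be ranked against one another on these data.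

Compound 4 `Cc1ccc(Cl)c(NS(=O)(=O)c2ccc(-c3cnc(C4CC4)o3)cc2)c1` is not yet measured. It differs from compound 2 in one place: 2-chloro-5-methylphenyl in place of 3-chloro-4-fluorophenyl on a sulfonamide nitrogen. Among the compounds with values here, the steps that bear on this change are the aryl swaps on the sulfonamide nitrogen already seen, a 1.5-fold higher number from compound 1 to compound 2 (0.17 log units; within the scatter) and a 1.5-fold higher number from compound 1 to compound 3 (0.18 log units; within the scatter), and the single-group exchange a 1.0-fold higher number from compound 2 to compound 3 (0.01 log units; within the scatter); none of them moved the read-out beyond the scatter. Compound 1, which carries the 2-chlorophenyl group, gives 49700 nM, in the same band as the others.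

On that basis no step beyond the scatter is expected for compound 4 in this assay, and the number is expected to fall in the same band, estimated at 55000 nM (range 25000 nM to 120000 nM), corresponding to an expected step of a 1.3-fold lower number from compound 2 to compound 4 (0.13 log units; within the scatter).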

Compound 4, concentration for total growth inhibition: 52800 nM
Estimate against measurement, compound 4: 1.0-fold (0.02 log units) above; measured number inside the range.
By their numbers in this assay, from the lowest: compounds 1, 4, 2 and 3 (each within the scatter of the next).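

In this assay the 2-chloro-5-methylphenyl group on the sulfonamide nitrogen stands level with both 3-chloro-4-fluorophenyl (a 1.4-fold lower number from compound 2 to compound 4 (0.14 log units; within the scatter)) and 4-fluoro-3-methoxyphenyl (a 1.4-fold lower number from compound 3 to compound 4 (0.16 log units; within the scatter)). Within the data shown here, the new information is the single exchange of methyl in place of hydrogen on an aromatic carbon, which also stays within the scatter (a 1.1-fold higher number from compound 1 to compound 4 (0.03 log units; within the scatter)). All four aryl groups on this nitrogen therefore sit in one band, with or without fluorine, methoxy or methyl, and the compounds cannot be ranked.

As far as these compounds go, whether an aryl group carrying an amine or a carboxylic acid, or a longer chain on this nitrogen, would leave that band remains open. Nothing at hand offers an explanation for the flat response at this position.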